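Series notes: heterocycle swap at the branched carbon of compound 1

A few compounds are considered here, and "the series" means these few. Any claim that something is new, unique, unknown or untested is made for them only; others in the source may bear on it.

Measured compounds:
compound 1 `CC(C)C(c1ccc(-c2ccc3cccc(F)c3c2)[nH]c1=O)N1CCCCS1(=O)=O` — 14 nM
compound 2 `CCn1ncc2c(C)cc(-c3ccc([C@@]4(C)CCNC4=O)c(=O)[nH]3)cc21` — 5 nM
compound 3 `CCC(CC)(c1nnc[nH]1)c1ccc(-c2ccc3cccc(F)c3c2)[nH]c1=O` — 19 nM

In an assay on CHO cells for displacement of a labelled ligand from prostaglandin E2 receptor EP3 subtype (Homo sapiens), read by radioligand binding (a lower number here means a stronger inhibitor, a higher number a weaker inhibitor), compound 1 gives 14 nM, the second highest of the three numbers. Its nearest neighbour is compound 3, whose number is higher by a margin that stays within the scatter; compound 2 sits furthest off, with a lower number that lies beyond the scatter. Compound 4 `Cc1nc(C(c2ccc(-c3ccc4cccc(F)c4c3)[nH]c2=O)C(C)C)[nH]c1C` has not been measured in this assay. It differs from compound 1 by a group of 7 heavy atoms (5 carbon, 2 nitrogen; one five-membered aromatic ring with 2 hetero atoms) in place of a group of 8 heavy atoms (4 carbon, 1 nitrogen, 2 oxygen, 1 sulfur; one six-membered non-aromatic ring with 2 hetero atoms), on a saturated chain carbon bound to an aromatic carbon and a saturated chain carbon. Among the measured compounds shown here, no step between measured compounds isolates this change, but compound 3, which carries a five-membered aromatic heterocycle at a branched carbon, gives 19 nM, close to compound 1. The change is therefore expected to shift the number little, if at all beyond the scatter, with a slight lean toward a higher number. For compound 4 the estimate is 20 nM, range 7 nM to 60 nM, an expected step of a 1.4-fold higher number from compound 1 to compound 4 (0.15 log units; within the scatter).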

Compound 4, inhibition constant: 7 nM
For compound 4 the middle estimate is 2.9-fold (0.46 log units) above the measured one; the range from low to high includes it.
By their numbers in this assay, from the lowest: compounds 2, 4, 1 and 3 (each within the scatter of the next, the first and the last beyond it).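

On the saturated chain carbon bound to an aromatic carbon and a saturated chain carbon, 4,5-dimethyl-1H-imidazol-2-yl in place of the six-membered non-aromatic ring gives a 2.0-fold lower number from compound 1 to compound 4 (0.30 log units; within the scatter) in this assay and thus leaves the number level with compound 1. This first single-place step shows that a five-membered aromatic ring with a hydrogen-bond donor can replace that ring here without a change beyond the scatter. Nothing available accounts for the result. From the compounds shown here alone, whether the two methyl groups matter remains open, as does how an unsubstituted imidazol-2-yl, a simple amine or a carboxylic acid would read at this carbon.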